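Aryl swaps on a shared core: expectation for compound 4

The source may report more compounds than this note shows. Statements on the series, on what has been measured and on what is new or still open speak of the compounds shown alone.

Measured in a functional assay on NCI-H226 cells (Homo sapiens) for inhibition, read by MTT assay, with a stated time of 48 h, tested at 10 uM; a higher number here means more inhibition at the concentration tested (going by the name of the read-out), a lower number less inhibition:
compound 1, `COc1cc(NC(=O)Nc2cc(Nc3ccc(OC)c(C)c3)ncn2)cc(OC)c1`, gives 39.7%
compound 2, `COc1cc(NC(=O)Nc2cc(Nc3cc(Br)ccc3OC)ncn2)cc(OC)c1`, gives 42.7%
compound 3, `COc1cc(NC(=O)Nc2cc(Nc3cc(C)cc(F)c3)ncn2)cc(OC)c1`, gives 35.3%

All three share one core and differ only in the aryl group carried on a nitrogen on an aromatic ring. Compound 3 sits at the low end of the three numbers, but neither gap reaches beyond the usual scatter: a number 4.4 percentage points lower from compound 1 to compound 3 (within the scatter) and a number 7.4 percentage points lower from compound 2 to compound 3 (within the scatter). The remaining pair behaves the same way, a number 3 percentage points higher from compound 1 to compound 2 (within the scatter). Across three different aryl groups, then, this assay has not registered a step that can be told apart from repeat-measurement noise.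

Compound 4, `COc1cc(NC(=O)Nc2cc(Nc3ccc(F)c(Cl)c3)ncn2)cc(OC)c1`, has not yet been measured. Its difference from compound 3 is 3-chloro-4-fluorophenyl in place of 3-fluoro-5-methylphenyl on a nitrogen on an aromatic ring. Among the measured compounds shown here, the three measured steps are the only guide, and each is the same kind of move, an exchange of the aryl group on that nitrogen; every one of them stayed within the scatter. The expectation for this assay is therefore a step of a number 2.7 percentage points higher from compound 3 to compound 4 (within the scatter), with no direction claimed beyond the scatter. Compound 4 is accordingly estimated to give 38%, expected to fall between 26% and 50%.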

Compound 4, a percentage reported as inhibition, at one concentration (the size of the read-out at that concentration, not a potency): 36.7%
Beside the measured number, compound 4's estimate is 1.3 percentage points above it, and the stated range covers the measured number.
By their numbers in this assay, from the lowest: compounds 3, 4, 1 and 2 (each within the scatter of the next).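

In this assay, among the compounds shown here, 3-chloro-4-fluorophenyl on a nitrogen on an aromatic ring puts chlorine on this aryl group for the first time in the set, and the result reads a number 1.4 percentage points higher from compound 3 to compound 4 (within the scatter), a number 6 percentage points lower from compound 2 to compound 4 (within the scatter) and a number 3 percentage points lower from compound 1 to compound 4 (within the scatter). The earlier compounds shown here covered only methyl, methoxy, fluorine and bromine on the aryl group, so this adds a fourth aryl group and a second pattern with two halogens to the exchanges at this position, and none of the steps to it can be told apart from repeat-measurement noise. No available measurement bears on why the four numbers stay within the scatter of each other.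

On these data alone, all four groups are carbon-only aromatic rings carrying halogen, methyl or methoxy, so it remains open whether an aryl group bearing an amine or a carboxylic acid, or a longer chain in place of the aryl group, would give a step beyond the scatter. Since each number comes from a single concentration, the compounds shown also leave open whether potency differs among them at all.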